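A few compounds are considered here, and "the series" means these few. Any claim that something is new, unique, unknown or untested is made for them only; others in the source may bear on it.

Measured in an ADME assay on MT4 cells (Homo sapiens) for cytotoxicity, read by MTT assay; on this read-out lower numbers stand for higher toxicity in this test and higher numbers for lower toxicity in this test:
Compound 1 `CC(=O)c1ccc(NC(=O)CSc2nncnc2-c2cccc3ccccc23)c(Br)c1`: 133000 nM
Compound 2 `Cc1ccccc1NC(=O)CSc1nncnc1-c1cccc2ccccc12`: 158000 nM
Compound 3 `O=C(CSc1nncnc1-c1cccc2ccccc12)Nc1ccccc1`: 154000 nM

Compound 3, at 154000 nM, lies within the scatter of both compound 1 and compound 2, so these numbers cannot be told apart. The next compound, compound 4 `O=C(CSc1nncnc1-c1cccc2ccccc12)Nc1ccccc1F`, has fluoro in place of hydrogen on an aromatic carbon, ortho to a large group: fluoro in place of hydrogen on an aromatic carbon.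

Among the measured compounds shown here, no measured step swaps in fluoro, so the evidence is indirect. The closest parallel is a 1.0-fold lower number from compound 2 to compound 3 (0.01 log units; within the scatter), where hydrogen replaces methyl on an aromatic carbon. Bigger swaps on the amide-type nitrogen also left the number within the scatter: a 1.2-fold higher number from compound 1 to compound 3 (0.06 log units; within the scatter) and a 1.2-fold higher number from compound 1 to compound 2 (0.07 log units; within the scatter). With three compounds, this is only a narrow basis, but it points to no step beyond the scatter for this smaller change, and no direction can be favoured.

The expected change is a 1.0-fold lower number from compound 3 to compound 4 (0.01 log units; within the scatter).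

For compound 4, the estimated value in this assay is 150000 nM, with an expected range from 100000 nM to 220000 nM.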

Compound 4, half-maximal cytotoxic concentration: 65000 nM
Estimate against measurement, compound 4: 2.3-fold (0.36 log units) above; the measured number lies below the stated range.
By their numbers in this assay, from the lowest: compound 4; then compounds 1, 3 and 2 (each within the scatter of the next).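

In this assay this position proves responsive to a single added atom: there is a 2.4-fold lower number from compound 3 to compound 4 (0.37 log units; beyond the scatter) when fluoro replaces hydrogen, whereas the swap of hydrogen for methyl at this position gave only a 1.0-fold lower number from compound 2 to compound 3 (0.01 log units; within the scatter) and stayed within the scatter. Fluoro in place of methyl gives a 2.4-fold lower number from compound 2 to compound 4 (0.39 log units; beyond the scatter) and the 2-fluorophenyl group in place of 4-acetyl-2-bromophenyl gives a 2.0-fold lower number from compound 1 to compound 4 (0.31 log units; beyond the scatter) so both comparisons also pass beyond the scatter. Compound 4 therefore has the lowest number of the four, which on this read-out stands for the highest toxicity in this test, although the steps are modest. Nothing available here accounts for this drop in the number. Going by these compounds, it remains open whether chloro, methoxy or an amine on this same aromatic carbon would lower the number as fluoro does or leave it within the scatter.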